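Taking one methoxy from the 3,4,5-trimethoxyphenyl group

The source may hold more compounds than are shown below. What is called first, only, known or untested is meant among the compounds shown, and "the series" means these compounds.

compound 1 `COc1cc(/C=C/C(=O)/C=C/c2cccc3ccccc23)ccc1OCc1cn(CCOc2cc(=O)oc3ccccc23)nn1` gives 20%
compound 2 `COc1cc(/C=C/C(=O)/C=C/c2cc(OC)c(OC)c(OC)c2)ccc1OCc1cn(CCOc2cc(=O)oc3ccccc23)nn1` gives 22%

Going by the values given here, both values come from a functional assay on PC-3 cells (Homo sapiens) for inhibition, read by sulforhodamine B assay, with a stated time of 48 h, tested at 50 uM (on this read-out higher numbers stand for more inhibition of growth at the one concentration tested and lower numbers for less inhibition of growth), and compound 2 lies within the scatter of compound 1, the only other compound measured so far. Next comes compound 3 `COc1ccc(/C=C/C(=O)/C=C/c2ccc(OCc3cn(CCOc4cc(=O)oc5ccccc45)nn3)c(OC)c2)cc1OC`, which has not yet been measured. It differs from compound 2 by hydrogen in place of methoxy on an aromatic carbon, so that 3,4,5-trimethoxyphenyl becomes 3,4-dimethoxyphenyl. Among the compounds with values here, one measured step bears on this same group: a number 2 percentage points higher from compound 1 to compound 2 (within the scatter), where 3,4,5-trimethoxyphenyl stands in place of naphthalen-1-yl. That exchange of a whole group stayed within the scatter. For the loss of a single methoxy in this assay, no step beyond the scatter is therefore expected, in either direction. The estimated step is a number 1 percentage points lower from compound 2 to compound 3 (within the scatter) in this read-out. Compound 3 is expected at 21%, with an estimated range from 10% to 34%.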

Compound 3, percent growth inhibition at one concentration: 19%
Compound 3: the middle estimate sits 2 percentage points above what was measured; low and high end bracket the measured number.
By their numbers in this assay, from the lowest: compounds 3, 1 and 2 (each within the scatter of the next).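

In this assay, going by these compounds alone, the loss of one methoxy from the 3,4,5-trimethoxyphenyl group gives the first direct reading of a single substituent at this place, and it does not separate the two compounds (a number 3 percentage points lower from compound 2 to compound 3 (within the scatter)). The 3,4-dimethoxyphenyl group also stays within the scatter of the naphthalen-1-yl group (a number 1 percentage points lower from compound 1 to compound 3 (within the scatter)), so neither this single methoxy nor the exchange of the whole group has yet moved the read-out beyond the scatter. Nothing available alongside these numbers accounts for this flat result.

The compounds shown leave open whether an amine or a carboxylic acid on this aromatic ring would move the read-out beyond the scatter. They also leave open whether losing the remaining methoxy groups, down to an unsubstituted phenyl, would do so.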